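This account rests on a few compounds, and the source may have more. Where it says the series, first, only, none or still open, it means among the compounds named here.

Measured so far in a functional assay on DLD-1 cells (Homo sapiens) for inhibition, read by luminescence, with a stated time of 3 days (on this read-out lower numbers stand for stronger inhibition of growth and higher numbers for weaker inhibition of growth), are three compounds.

- compound 1 `CC[C@@H]1CC[C@@H](C(=O)N2CCN(C(C)=O)CC2)N1C(=O)C1=C(C(C)C)N2C(=N[C@@](C)(c3ccc(Cl)cc3)[C@H]2c2ccc(Cl)cc2)S1` gives 9300 nM 
- compound 2 `CC(=O)N1CCN(C(=O)[C@@H]2CC[C@@H](C)N2C(=O)C2=C(C(C)C)N3C(=N[C@@](C)(c4ccc(Cl)cc4)[C@H]3c3ccc(Cl)cc3)S2)C[C@@H]1C` gives 5200 nM 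
- compound 3 `CC[C@@H]1CC[C@@H](C(=O)N2CCN(C)[C@H](C)C2)N1C(=O)C1=C(C(C)C)N2C(=N[C@@](C)(c3ccc(Cl)cc3)[C@H]2c2ccc(Cl)cc2)S1` gives 3600 nM 

Compound 3 and compound 2 lie within the scatter of each other at the low end of these numbers, while compound 1 stands clearly higher. Compound 4 `CC[C@@H]1CC[C@@H](C(=O)N2CCN(C(C)=O)[C@@H](C)C2)N1C(=O)C1=C(C(C)C)N2C(=N[C@@](C)(c3ccc(Cl)cc3)[C@H]2c2ccc(Cl)cc2)S1` differs from compound 3 by a group of 10 heavy atoms (7 carbon, 2 nitrogen, 1 oxygen; one six-membered non-aromatic ring with 2 hetero atoms) in place of a group of 8 heavy atoms (6 carbon, 2 nitrogen; one six-membered non-aromatic ring with 2 hetero atoms), on a carbonyl carbon, and the 3,4-dimethylpiperazin-1-yl group is the one that leaves.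

Among the measured compounds shown here, one measured step bears on this place: a 2.6-fold lower number from compound 1 to compound 3 (0.41 log units; beyond the scatter), with 3,4-dimethylpiperazin-1-yl in place of 4-acetylpiperazin-1-yl. The change to compound 4 moves away from 3,4-dimethylpiperazin-1-yl, but the entering group is not 4-acetylpiperazin-1-yl itself, so only part of that modest step is expected to return. Compound 2, with a closely similar group and a different substituent elsewhere on the shared core, gives 5200 nM and points to the same range. With only these three values, the support is thin.

In this assay a small move toward a higher number is therefore expected, and the estimated change is a 1.7-fold higher number from compound 3 to compound 4 (0.22 log units; within the scatter). For compound 4 the estimated value is 6000 nM (expected range 3000 nM to 12000 nM).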

Compound 4, concentration for 50% growth inhibition: 2600 nM
Compound 4: the middle estimate sits 2.3-fold (0.36 log units) above what was measured; the whole stated range lies above it.
By their numbers in this assay, from the lowest: compounds 4, 3, 2 and 1 (each within the scatter of the next, the first and the last beyond it).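

In this assay, putting the entering group on the carbonyl carbon in place of 3,4-dimethylpiperazin-1-yl gives a 1.4-fold lower number from compound 3 to compound 4 (0.14 log units; within the scatter), so at this place the two groups are not told apart, and restoring the acetyl carbonyl does not bring back the higher number of compound 1. The one-place step that isolates the ring methyl, methyl in place of hydrogen on a saturated ring carbon, gives a 3.6-fold lower number from compound 1 to compound 4 (0.55 log units; beyond the scatter), which lies beyond the scatter and shows that this methyl alone is enough to separate an acetylated piperazine from compound 1. Methyl in place of hydrogen on a saturated chain carbon bound to a saturated ring carbon gives a 2.0-fold lower number from compound 2 to compound 4 (0.30 log units; within the scatter), which is within the scatter, so that change elsewhere on the shared core is not resolved here.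

Nothing available explains why the ring methyl matters or why the two groups read alike. Still open, on these data alone, is whether the tolerance at this place extends to a propanoyl group, a free piperazine amine or a carboxylic acid in the entering group, and whether a longer chain than methyl on the same ring carbon would hold the number of compound 4.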